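A few compounds are considered here, and "the series" means these few. Any claim that something is new, unique, unknown or untested is made for them only; others in the source may bear on it.

Series notes. The shared core of compound 1 `Cc1cccc(Cn2cc(COc3ccc4c(=O)ccoc4c3)nn2)c1` carries a 3-methylphenyl group on the saturated chain carbon bound to the aromatic nitrogen; in a functional assay on SW480 cells (Homo sapiens) for cytotoxicity, read by MTT assay, with a stated time of 48 h (on this read-out lower numbers stand for stronger inhibition and higher numbers for weaker inhibition), compound 1 gives 11700 nM. Compound 2 `Cc1ccc(Cn2cc(COc3ccc4c(=O)ccoc4c3)nn2)cc1` moves the methyl to the 4-position, and in this assay compound 2 gives 10400 nM. Compound 3 `O=c1ccoc2cc(OCc3cn(Cc4cccc(Cl)c4)nn3)ccc12` carries a 3-chlorophenyl group instead; in this assay compound 3 gives 12900 nM. Among the three numbers compound 2 has the lowest, but the step of a 1.1-fold lower number from compound 1 to compound 2 (0.05 log units; within the scatter) and the step of a 1.2-fold higher number from compound 2 to compound 3 (0.09 log units; within the scatter) are both within the scatter, as is a 1.1-fold higher number from compound 1 to compound 3 (0.04 log units; within the scatter), so no ordering can be read from them.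

Compound 4 `CC(C)(C)c1ccc(Cn2cc(COc3ccc4c(=O)ccoc4c3)nn2)cc1` takes the step from compound 2 described as tert-butyl in place of methyl on an aromatic carbon. Within the data shown here, no measured step enlarges a substituent on this phenyl ring; the three steps seen only move a methyl or exchange it for chloro, and each stays within the scatter. The nearest reference is therefore the flat behaviour of compounds 1, 2 and 3 at the same position, which gives no reason to expect a step beyond the scatter in this assay in either direction.

Compound 4 is accordingly expected near 10000 nM, the step of a 1.0-fold lower number from compound 2 to compound 4 (0.02 log units; within the scatter) being the estimate, with a range from 4500 nM to 22000 nM.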

Compound 4, half-maximal inhibitory concentration: 28800 nM
The estimate for compound 4 lay 2.9-fold (0.46 log units) below the measured number; measured number above the stated range.
By their numbers in this assay, from the lowest: compounds 2, 1 and 3 (each within the scatter of the next); then compound 4.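

In this assay, among these compounds, the ring on the saturated chain carbon no longer looks flat: a 2.8-fold higher number from compound 2 to compound 4 (0.44 log units; beyond the scatter), the first step that lies beyond the scatter, and it runs towards weaker inhibition. Among the compounds shown here, the change is tert-butyl, with 4 heavy atoms, in place of methyl, with 1 heavy atom; no ring, hydrogen-bond donor, hydrogen-bond acceptor or net charge enters, so this position is not indifferent to every substituent, even though moving the methyl or exchanging it for chloro stayed within the scatter, and this reading rests on the single pair of compound 2 and compound 4. Nothing in the available data accounts for this loss.

The compounds shown leave open whether an ethyl or isopropyl group on this aromatic carbon would already give a step beyond the scatter, or whether the rise in the number appears only with tert-butyl. They also leave open whether a dimethylamino group or a carboxylic acid on the same carbon would shift the number in the same direction.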